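This account rests on a few compounds, and the source may have more. Where it says the series, first, only, none or still open, it means among the compounds named here.

Compound 3 `Cc1cc(C(=O)Nc2cccc(-c3oc4cc(-c5ccc(F)cc5)ccc4c(=O)c3O)c2)ccc1F` sits at the low end of the numbers shown in a functional assay on HepG2 cells (Homo sapiens) for antiproliferative activity, read by CCK-8 assay, with a stated time of 72 h (a lower number here means a stronger inhibitor, a higher number a weaker inhibitor), where compound 3 gives 9540 nM. Compound 1 `O=C(Nc1cccc(-c2oc3cc(-c4ccc(F)cc4)ccc3c(=O)c2O)c1)c1ccccc1F` gives 10100 nM in this assay, and the pair is indistinguishable: a 1.1-fold lower number from compound 1 to compound 3 (0.02 log units; within the scatter). Compound 2 `O=C(Nc1cccc(-c2oc3cc(-c4ccc(F)cc4)ccc3c(=O)c2O)c1)c1ccc(C(F)(F)F)cc1` gives 42700 nM; the swap of the aryl group on the carbonyl carbon reads a 4.5-fold lower number from compound 2 to compound 3 (0.65 log units; beyond the scatter), and likewise a 4.2-fold higher number from compound 1 to compound 2 (0.63 log units; beyond the scatter). Compound 4 `O=C(Nc1cccc(-c2oc3cc(-c4ccc(F)cc4)ccc3c(=O)c2O)c1)c1cnc(Cl)nc1Cl` carries the same kind of change: 2,4-dichloropyrimidin-5-yl in place of 4-fluoro-3-methylphenyl on a carbonyl carbon. Two of the three measured aryl swaps moved this assay modestly and one not at all, so a modest step is expected, and the direction cannot be fixed from these data alone; the estimated step is a 2.1-fold higher number from compound 3 to compound 4 (0.32 log units; beyond the scatter). Compound 4 is therefore expected to give 20000 nM in this assay, within 6000 nM to 60000 nM.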

Compound 4, half-maximal inhibitory concentration: > 100000 nM
Compound 4 ended at the assay's limit; the forecaster's own chance of this, stated with the estimate: 10%; middle value at least 5.0-fold (0.69 log units) away from the limit.
By their numbers in this assay, from the lowest: compounds 3 and 1 (each within the scatter of the next); then compound 2. At a limit, above all of these: compound 4.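

In this assay compound 4 reads only as a limit, not as a number: the limit of > 100000 nM in this assay, at which 1 of the 4 values shown sits. The 2,4-dichloropyrimidin-5-yl group on this carbonyl carbon gives an at least 10-fold higher number from compound 3 to compound 4 (1.02 log units; beyond the scatter), an at least 9.9-fold higher number from compound 1 to compound 4 (0.99 log units; beyond the scatter) and an at least 2.3-fold higher number from compound 2 to compound 4 (0.36 log units; beyond the scatter). Going by these compounds alone, the earlier aryl swaps at this position showed nothing larger than modest steps, so this change is the first to show that the position can carry the number out to the limit. The compounds shown do not separate the effect of the ring nitrogens from that of the chlorine atoms, and they leave open how a 2,4-dichlorophenyl or an unsubstituted pyrimidin-5-yl group would read in this assay.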